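The source may report more compounds than this note shows. Statements on the series, on what has been measured and on what is new or still open speak of the compounds shown alone.

In a functional assay on SK-MEL-28 cells (Homo sapiens) for inhibition, read by MTT assay, with a stated time of 72 h (a higher number here means a weaker inhibitor of growth, a lower number a stronger inhibitor of growth), compound 1 `CC1(C)CCC[C@]2(C)[C@@H](C=O)C(C=O)=CC[C@@H]12` gives 65000 nM and compound 2 `CC(C)(C)OC(=O)/C=C/C1=CC[C@H]2C(C)(C)CCC[C@]2(C)[C@H]1C=O` gives 41000 nM on the same read-out. These two numbers lie within the usual scatter of each other, so the two compounds cannot be told apart here. Among the measured compounds shown here, no two measured compounds differ in just one place, which leaves no measured step to serve as a guide.

Compound 3 `C#CCCCOC(=O)/C=C/C1=CC[C@H]2C(C)(C)CCC[C@]2(C)[C@H]1C=O` has pent-4-yn-1-yl in place of tert-butyl on an oxygen next to a carbonyl group of compound 2, and the full count of that change reads pent-4-yn-1-yl in place of tert-butyl on an oxygen next to a carbonyl group with the rest of the structure unchanged. The data give no sign of which way such a swap should move the number, so no clear shift is expected in this assay. Compound 2 at 41000 nM is the anchor for this expectation. The expected change is a 1.2-fold lower number from compound 2 to compound 3 (0.07 log units; within the scatter) and it stays within the scatter. For compound 3 the estimated value is 35000 nM with an expected range from 14000 nM to 80000 nM in this measurement.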

Compound 3, concentration for 50% growth inhibition: 36000 nM
Compound 3: the middle estimate sits 1.0-fold (0.01 log units) below what was measured, within the range that was stated.
By their numbers in this assay, from the lowest: compounds 3, 2 and 1 (each within the scatter of the next).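

Within this assay pent-4-yn-1-yl in place of tert-butyl on an oxygen next to a carbonyl group gives a 1.1-fold lower number from compound 2 to compound 3 (0.06 log units; within the scatter) and this is the first measured change in one place only. At this position, then, two quite different groups cannot be told apart by this read-out of growth inhibition, even though one of them carries a triple bond and has one more carbon. No measurement at hand offers an explanation for this result.

As far as these compounds go, a single swap cannot define what this position accepts, so it remains open whether a methyl group, a much longer chain or a chain ending in an amine on that same oxygen would also stay within the scatter of compound 2. From the compounds shown here alone, it is also open whether the triple bond plays any part of its own, since a plain pentyl chain on that oxygen would be the direct comparison with compound 3, and whether a carboxylic acid, with no group on that oxygen at all, would read any differently.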